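A few compounds are considered here, and "the series" means these few. Any claim that something is new, unique, unknown or untested is made for them only; others in the source may bear on it.

Of the compounds shown here, three built on one shared core have been tested in a functional assay on the whole organism for antagonist activity, with Mus musculus as the target; a higher number here means that more compound is needed for the effect, a lower number that less compound is needed. Compound 1 `COc1cc(N)c(Cl)cc1NC(=O)C1CCN(Cc2ccc(Cl)cc2)CC1` carries a chloro on an aromatic carbon and gives 1.2 mg/kg. Compound 2 `COc1cc(N)c(Cl)cc1NC(=O)C1CCN(Cc2ccccc2)CC1`, with hydrogen in that place, gives 0.5 mg/kg, which is a 2.4-fold lower number from compound 1 to compound 2 (0.38 log units; beyond the scatter). Compound 3 `COc1cc(N)c(Cl)cc1NC(=O)C1CCN(Cc2ccc(OCc3ccccc3)cc2)CC1` carries a benzyloxy there instead. In this assay compound 3 reaches only > 4 mg/kg, which is a limit of the assay and not a number. The steps that installed this benzyloxy are an at least 3.3-fold higher number from compound 1 to compound 3 (0.52 log units; beyond the scatter) and an at least 8.0-fold higher number from compound 2 to compound 3 (0.90 log units; beyond the scatter); both rest on (the limit of > 4 mg/kg in this assay, at which 1 of the 3 values shown sits).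

Compound 4 `COc1ccc(CN2CCC(C(=O)Nc3cc(Cl)c(N)cc3OC)CC2)cc1` has not yet been measured. It differs from compound 3 by hydrogen in place of phenyl on a saturated chain carbon bound to an oxygen on an aromatic ring, so the benzyloxy becomes a methoxy. The two steps that bear on this are the ones that brought the benzyloxy in, each at least modest and both raising the number; taking the phenyl away again is expected to move the number back down. A methoxy is not the hydrogen of compound 2, so not the whole of that rise need be recovered. For compound 4 the expected value in this assay is 1.5 mg/kg, within 0.5 mg/kg to 4 mg/kg. For compound 4 this means an expected step of an at least 2.6-fold lower number from compound 3 to compound 4 (0.42 log units; beyond the scatter).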

Compound 4, dose for half-maximal effect: 0.9 mg/kg
The estimate for compound 4 lay 1.7-fold (0.22 log units) above the measured number, within the range that was stated.
By their numbers in this assay, from the lowest: compounds 2, 4 and 1 (each within the scatter of the next, the first and the last beyond it). At a limit, above all of these: compound 3.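

Cutting the benzyloxy back to a methoxy gives an at least 4.4-fold lower number from compound 3 to compound 4 (0.64 log units; beyond the scatter) in this assay, so the high number of compound 3 goes with the phenyl at the end of that group, not with an oxygen on the aromatic carbon as such, and the true size of this step stays open: the limit of > 4 mg/kg in this assay, at which 1 of the 4 values shown sits.

The methoxy of compound 4 cannot be told apart from either neighbouring compound, with a 1.8-fold higher number from compound 2 to compound 4 (0.26 log units; within the scatter) and a 1.3-fold lower number from compound 1 to compound 4 (0.12 log units; within the scatter), both within the usual scatter, even though compound 1 and compound 2 differ from each other beyond it. Among these four compounds, then, a hydrogen, a chloro and a methoxy all give numbers of a similar order in this position, and only the benzyloxy of compound 3 stands clearly apart.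

The compounds shown do not say at what point between a methoxy and a benzyloxy the number starts to climb, which an ethoxy or a longer chain on that oxygen could help to settle. They also leave open how an amine or a carboxylic acid in this place would behave in this assay.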